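A few compounds are considered here, and "the series" means these few. Any claim that something is new, unique, unknown or untested is made for them only; others in the source may bear on it.

Compound 1 `CCCN(CCC)Cc1ccc(Cl)c(-c2ccccc2OC)c1` carries a dipropylamino group on a saturated chain carbon bound to an aromatic carbon. In an assay on HEK293 cells for displacement of a labelled ligand from 5-hydroxytryptamine receptor 7 (Homo sapiens), read by scintillation counting, with a stated time of 1.5 h (on this read-out lower numbers stand for stronger inhibition and higher numbers for weaker inhibition), compound 1 gives only a limit, > 10000 nM, and not a measured number. Compound 2 `COc1ccccc1-c1cc(C2CCN(C)C2)ccc1Cl`, built on the same core with a different amine, gives 30.2 nM; 30 nM (2 entries) in this assay. Compound 3 `COc1ccccc1-c1cc(CN(C)C)ccc1Cl` differs from compound 1 by dimethylamino in place of dipropylamino on a saturated chain carbon bound to an aromatic carbon. Going by the values given here, no measured pair shows this exact change, so the size of the step is open. Compound 3 is expected to reach about 300 nM, plausibly between 40 nM and 3000 nM. That expectation amounts to a step of an at least 33-fold lower number from compound 1 to compound 3 (1.52 log units; beyond the scatter) toward stronger binding.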

Compound 3, inhibition constant: 20 nM
For compound 3 the middle estimate is 15-fold (1.18 log units) above the measured one; measured number below the stated range.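

Putting dimethylamino in place of dipropylamino on a saturated chain carbon bound to an aromatic carbon brings an at least 500-fold lower number from compound 1 to compound 3 (2.69 log units; beyond the scatter) in this assay. For compound 1, > 10000 nM is a limit of the assay and not a number, so this step gives only the smallest possible size of the change. On this core, the amine at this one place is enough to separate a compound with a measured number from one with only a limit.

Where the number would fall with diethylamino at the same place stays open. The chain length at which binding falls away therefore cannot be told.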